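The source may report more compounds than this note shows. Statements on the series, on what has been measured and on what is new or still open speak of the compounds shown alone.

Of the compounds shown here, three that share one core have been measured in a functional assay on Huh-7 cells (Homo sapiens) for inhibition, read by sulforhodamine B assay; a higher number here means a weaker inhibitor, a lower number a stronger inhibitor. Compound 1 `C#CC(=O)N1C(C(CC)CCCC)SC[C@@H]1C(=O)OCC` gives 1700 nM, compound 2 `C#CC(=O)N1C(c2ccc(OC)cc2)SC[C@@H]1C(=O)OCC` gives 1400 nM, and compound 3 `C#CC(=O)N1C(c2ccccc2)SC[C@@H]1C(=O)OCC` gives 5300 nM. Compound 3 thus carries the highest number of the three, and both steps leading to it run upward: a 3.1-fold higher number from compound 1 to compound 3 (0.49 log units; beyond the scatter) and a 3.8-fold higher number from compound 2 to compound 3 (0.58 log units; beyond the scatter). Compound 4 `C#CC(=O)N1C(c2ccc(F)cc2)SC[C@@H]1C(=O)OCC` has not yet been measured. It differs from compound 3 by fluoro in place of hydrogen on an aromatic carbon. The step that bears most directly on this change is the one in which hydrogen replaced methoxy on an aromatic carbon, which raised the number modestly; that suggests a group on this aromatic carbon is tolerated, even helpful. Fluoro is a different and smaller group than methoxy, so only a small downward step, a 1.7-fold lower number from compound 3 to compound 4 (0.22 log units; within the scatter), is expected in this assay, a step that may well fall within the usual scatter. Compound 4 is estimated at 3200 nM, with a likely range from 1300 nM to 8000 nM.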

Compound 4, half-maximal inhibitory concentration: 700 nM
For compound 4 the middle estimate is 4.6-fold (0.66 log units) above the measured one; measured number outside the range, below it.
By their numbers in this assay, from the lowest: compounds 4, 2 and 1 (each within the scatter of the next, the first and the last beyond it); then compound 3.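

In this assay, a single fluorine atom on the phenyl gives the largest step seen in this set, a 7.6-fold lower number from compound 3 to compound 4 (0.88 log units; beyond the scatter). The methoxy of compound 2 is therefore not needed to lower the number at this aromatic carbon, since fluoro serves as well: a 2.0-fold lower number from compound 2 to compound 4 (0.30 log units; within the scatter). The 4-fluorophenyl also gives a lower number than the 1-ethylpentyl, a 2.4-fold lower number from compound 1 to compound 4 (0.39 log units; beyond the scatter), whereas plain phenyl gave a higher one, and no measurement available here explains these differences.

The compounds shown leave open whether this drop is particular to fluoro or would also appear with chloro, methyl or trifluoromethyl on the same carbon. They also leave open how a second fluoro on the ring, or a carboxylic acid in place of the ethyl ester, would move the number.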